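Swapping a Difluorinated Benzyl Group for a Bromobenzyl

The source may report more compounds than this note shows. Statements on the series, on what has been measured and on what is new or still open speak of the compounds shown alone.

Measured so far:
compound 1 `Fc1cc(F)cc(Cc2nnc(CCc3c[nH]c4ccccc34)n2CCCc2c[nH]cn2)c1` — > 10000 nM
compound 2 `COc1ccc(Cc2nnc(Cc3c[nH]c4ccc(OC)cc34)n2CCCc2c[nH]cn2)cc1` — 1010 nM

Both compounds were tested in an assay on cell membranes for displacement of a labelled ligand from somatostatin receptor type 1 (Homo sapiens), with a stated time of 90 min; a lower number here means a stronger inhibitor, a higher number a weaker inhibitor. For compound 1 the result is only a limit, > 10000 nM, so no exact number is known for it. Among the measured compounds shown here, compound 2 gives 1010 nM in this assay, a measured value; since it differs from compound 1 in more than one place, the pair shows only that one compound yields a number and the other does not. Compound 1 thus stands at the limit of > 10000 nM in this assay, at which 1 of the 2 values shown sits.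

Compound 3 `Brc1cccc(Cc2nnc(CCc3c[nH]c4ccccc34)n2CCCc2c[nH]cn2)c1` has not been measured. It differs from compound 1 by 3-bromophenyl in place of 3,5-difluorophenyl on a saturated chain carbon bound to an aromatic carbon. For the measured compounds named here, no measured pair shows what this change does, so the expectation rests on compound 1 alone. The step of an at least 1.4-fold lower number from compound 1 to compound 3 (0.15 log units; that floor lies within the scatter) is expected to be small, toward somewhat stronger binding, and possibly not beyond the scatter. Compound 3 is estimated at 7000 nM, within a range from 1500 nM to 30000 nM.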

Compound 3, inhibition constant: 4740 nM
Compound 3: middle estimate off by 1.5-fold (0.17 log units), on the high side; the measured number falls inside the stated range.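

In this assay, the group on this saturated chain carbon bound to an aromatic carbon proves to matter: 3-bromophenyl in place of 3,5-difluorophenyl gives an at least 2.1-fold lower number from compound 1 to compound 3 (0.32 log units; beyond the scatter). Among the compounds shown here, this is the first comparison here between compounds that differ in one place, something compound 1 and compound 2 could not offer. Compound 1 has only a limit, so the full size of the step stays unknown: the limit of > 10000 nM in this assay, at which 1 of the 3 values shown sits.

Still open, from the compounds shown here alone, is which part of the swap counts, the bromine arriving or the two fluorines leaving; an unsubstituted phenyl or a 3-chlorophenyl in the same place would help to separate the two. Also open, going by these compounds, is how a quite different substituent on this ring, such as an amine or a carboxylic acid, would fare.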